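Notes on the ether substituent of the shared core

The source may hold more compounds than are shown below. What is called first, only, known or untested is meant among the compounds shown, and "the series" means these compounds.

Measured in a functional assay on HEK293 cells for agonist activity at G-protein coupled receptor 39 (Homo sapiens), read by scintillation proximity assay and inositol phosphate accumulation, with a stated time of 75 min; on this read-out lower numbers stand for an effect already at smaller amounts and higher numbers for an effect only at larger amounts of compound:
compound 1 `Cc1nn(-c2ncnc3nc[nH]c23)c2c1C(OCCn1nccc1C)CC(=O)N2`: 1620 nM
compound 2 `Cc1nn(-c2ncnc3nc[nH]c23)c2c1C(OCc1ccc(F)cc1)CC(=O)N2`: 126 nM
compound 3 `Cc1nn(-c2ncnc3nc[nH]c23)c2c1C(OCc1ccccc1Cl)CC(=O)N2`: 47 nM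

Compound 3 gives the lowest number of the three. Its nearest neighbour is compound 2, separated by a 2.7-fold lower number from compound 2 to compound 3 (0.43 log units; beyond the scatter); furthest is compound 1, separated by a 34-fold lower number from compound 1 to compound 3 (1.54 log units; beyond the scatter). Compound 4 `Cc1nn(-c2ncnc3nc[nH]c23)c2c1C(OCc1cc(F)cc3c1OCOC3)CC(=O)N2` is not yet measured. The change from compound 3 is a group of 11 heavy atoms (8 carbon, 2 oxygen, 1 fluorine; one six-membered non-aromatic ring with 2 hetero atoms, one six-membered aromatic ring of carbon only) in place of a group of 7 heavy atoms (6 carbon, 1 chlorine; one six-membered aromatic ring of carbon only), on a saturated chain carbon bound to an oxygen on a saturated carbon. All three measured steps concern this same place: a 13-fold lower number from compound 1 to compound 2 (1.11 log units; beyond the scatter) and a 34-fold lower number from compound 1 to compound 3 (1.54 log units; beyond the scatter) were large, while the exchange of one substituted phenyl for another, a 2.7-fold lower number from compound 2 to compound 3 (0.43 log units; beyond the scatter), was modest. Among the compounds with values here, the entering group has no direct precedent here, so a modest step is expected, most likely upward from compound 3. Compound 4 is estimated at 110 nM, within 30 nM to 400 nM, meaning an expected step of a 2.3-fold higher number from compound 3 to compound 4 (0.37 log units; beyond the scatter).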

Compound 4, half-maximal effective concentration: 30 nM
Estimate against measurement, compound 4: 3.7-fold (0.56 log units) above; the range from low to high includes it.
By their numbers in this assay, from the lowest: compounds 4 and 3 (each within the scatter of the next); then compound 2; then compound 1.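

The group of 11 heavy atoms, with its added six-membered non-aromatic ring, is tolerated at this place, with a 1.6-fold lower number from compound 3 to compound 4 (0.19 log units; within the scatter) and so no separation from the 2-chlorophenyl. Gaps to the other two substituents remain, with a 4.2-fold lower number from compound 2 to compound 4 (0.62 log units; beyond the scatter) and a 54-fold lower number from compound 1 to compound 4 (1.73 log units; beyond the scatter) as steps beyond the scatter. Nothing at hand gives a reason for these steps.

Which part of the entering group, the fluorine or the non-aromatic ring, shapes the number stays open. So does the outcome of an amine or a carboxylic acid on the phenyl ring at this place.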